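The source may report more compounds than this note shows. Statements on the series, on what has been measured and on what is new or still open speak of the compounds shown alone.

Compound 1 `COc1cc2nc(C3CCC3)nc(N3CCN(c4ccccc4Cl)CC3)c2cc1OC` gives in an in vitro assay on U2OS cells for agonist activity at neurotensin receptor type 2 (Homo sapiens), read by reporter gene assay and beta-arrestin recruitment (on this read-out higher numbers stand for an effect only at larger amounts of compound and lower numbers for an effect already at smaller amounts), only a limit of the assay, > 80000 nM. Compound 2 `CCOc1ccccc1N1CCN(c2nc(C3CC3)nc3cc(OC)c(OC)cc23)CC1` likewise gives in this assay only a limit, > 80000 nM. Both readings sit at the limit of > 80000 nM in this assay, at which 2 of the 2 values shown sit, so compound 2 stands at the same limit as compound 1, with no number by which either could be ranked. Compound 3 `COc1cc2nc(C3CC3)nc(N3CCN(c4ccccc4Cl)CC3)c2cc1OC` differs from compound 2 by chloro in place of ethoxy on an aromatic carbon. Among the compounds with values here, no measured step exists, and no shift beyond the scatter is expected in this assay. Compound 3 is expected to give about 100000 nM, within 30000 nM to 300000 nM, most likely again only as a limit. The expected step from compound 2 to compound 3 is a step that the limit leaves unreadable from compound 2 to compound 3.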

Compound 3, half-maximal effective concentration: > 80000 nM
Compound 3: only a limit was reported; the forecaster's own chance of this, stated with the estimate: 90%; the middle value lies beyond the limit too.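

No step can be read among compound 1, compound 2 and compound 3, since all three give only a limit: the limit of > 80000 nM in this assay, at which 3 of the 3 values shown sit.

Left open is how chloro compares with ethoxy, or cyclopropyl with cyclobutyl, in this assay.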